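Bromo in place of nitro on the benzylamine arm

The source may report more compounds than this note shows. Statements on the series, on what has been measured and on what is new or still open speak of the compounds shown alone.

This account concerns three measured compounds sharing one core and a fourth that awaits measurement. Compound 1 `O=[N+]([O-])c1ccccc1CNc1cc(Br)cc2cn[nH]c12` gives 48% in an assay for inhibition of Tryptophan 2,3-dioxygenase (Homo sapiens), with stated times of 10 min and 60 min, tested at 100 uM; on this read-out higher numbers stand for a stronger effect at the one concentration tested and lower numbers for a weaker effect. Compound 2 `FC(F)(F)c1cc(NCc2cccc3sccc23)c2cn[nH]c2c1` gives 5% in this assay. Compound 3 `O=[N+]([O-])c1cccc(CNc2cc(C(F)(F)F)cc3[nH]ncc23)c1` gives 82% in this assay, the highest of the three numbers; its nearest neighbour is compound 1, whose number lies beyond the scatter below it, and the furthest is compound 2, whose number lies far beyond the scatter below it.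

Compound 4 `FC(F)(F)c1cc(NCc2cccc(Br)c2)c2cn[nH]c2c1` differs from compound 3 in one place: bromo in place of nitro on an aromatic carbon. Within the data shown here, no step between measured compounds isolates this change, so the two structures alone must carry the expectation. The two compounds that carry a nitro group, compound 1 and compound 3, give the two larger numbers, while compound 2, which carries no nitro group, gives the smallest; this is only three points and no pattern is claimed beyond them.

On that basis compound 4 is expected to lose inhibition, with an estimated step of a number 42 percentage points lower from compound 3 to compound 4 (beyond the scatter) beyond the scatter and downward. Compound 4 is estimated to give 40% in this assay, within a range from 10% to 70%.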

Compound 4, a percentage reported as inhibition, at one concentration (the size of the read-out at that concentration, not a potency): 84%
Compound 4: middle estimate off by 44 percentage points, on the low side, outside the stated range (above it).
By their numbers in this assay, from the lowest: compound 2; then compound 1; then compounds 3 and 4 (each within the scatter of the next).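

In this assay, bromo in place of nitro on an aromatic carbon, meta to a large group, gives a number 2 percentage points higher from compound 3 to compound 4 (within the scatter), so at the one concentration tested this read-out does not separate the two groups at this position. Nitro is therefore not required here for a large number: compound 4 carries no nitro group, and it goes against the link between nitro and the larger numbers that the first three compounds seemed to suggest. Nothing in the data explains why two such different groups read alike on this core.

The compounds shown leave open whether an amine, a carboxylic acid, a nitrile or a plain hydrogen at this position would hold the number, or whether the read-out depends on having some substituent there at all. They also leave open whether the same exchange would behave alike on the other substituted forms of the shared core, and whether compound 3 and compound 4 would still read alike in a full potency measurement rather than at a single concentration.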